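A few compounds are considered here, and "the series" means these few. Any claim that something is new, unique, unknown or untested is made for them only; others in the source may bear on it.

Three compounds sharing one core were tested in an ADME assay on RD cells (Homo sapiens) for cytotoxicity; a higher number here means that more compound is tolerated, a lower number that less compound is tolerated. Compound 1, `O=C1/C(=N\NC(=S)Nc2ccccc2)c2ccccc2N1c1ccccc1`, gives a value that is a limit of the assay rather than a number, > 25000 nM. Compound 2, `CNC(=S)N/N=C1\C(=O)Nc2ccccc21`, likewise reaches only a limit, > 25000 nM. Compound 3, `Cc1ccc(NC(=O)N/N=C2\C(=O)Nc3ccccc32)cc1`, also stops at a limit, > 25000 nM. So compound 2 stands exactly where everything measured so far stands, at the limit of > 25000 nM in this assay, at which 3 of the 3 values shown sit, and no number separates it from the other two.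

Compound 4, `CCCNC(=S)N/N=C1\C(=O)Nc2ccccc21`, is not yet measured. It differs from compound 2 in one place: ethyl in place of hydrogen on a saturated chain carbon bound to an amide-type nitrogen. Read one bond further out, the methylamino of compound 2 becomes propylamino.

Because every value in hand sits at the limit of > 25000 nM in this assay, at which 3 of the 3 values shown sit, the step of a number no higher from compound 2 to compound 4 (the limit leaves the size open) is expected to be none beyond the usual scatter, in either direction. Compound 4 is therefore expected to land near 25000 nM, between 12500 nM and 50000 nM, and most probably to be reported once more as a limit.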

Compound 4, half-maximal cytotoxic concentration: > 25000 nM
Compound 4 ended at the assay's limit; the forecaster's own chance of this, stated with the estimate: 85%; the middle value lies on the limit itself.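

Going by these compounds alone, compound 2 and compound 4 both end at a limit rather than a number, so no step between them can be read. The compounds shown leave open at what concentration, if any, any of them would become toxic to the cells in this assay, and all the values give only this: the limit of > 25000 nM in this assay, at which 4 of the 4 values shown sit.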